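A few compounds are considered here, and "the series" means these few. Any claim that something is new, unique, unknown or untested is made for them only; others in the source may bear on it.

Measured in a functional assay on DU-145 cells (Homo sapiens) for inhibition, read by trypan blue exclusion, with a stated time of 96 h; on this read-out lower numbers stand for stronger inhibition of growth and higher numbers for weaker inhibition of growth:
- compound 1 `O=C(O)c1ccc(C(=O)/C(=C\c2ccc(Cl)c([N+](=O)[O-])c2)SCc2ccc(Cl)cc2)cc1`: 1000 nM
- compound 2 `O=C(O)c1ccc(C(=O)/C(=C\c2ccc(Br)cc2)SCc2ccc(F)cc2)cc1`: > 100000 nM, a limit of the assay
- compound 3 `O=C(O)c1ccc(C(=O)/C(=C\c2ccc(Cl)c([N+](=O)[O-])c2)SCc2ccc(C(F)(F)F)cc2)cc1`: 1000 nM

Compound 3 stands at 1000 nM, level with compound 1. Compound 4 `O=C(O)c1ccc(C(=O)/C(=C\c2ccc(Cl)c([N+](=O)[O-])c2)SCc2ccc(F)cc2)cc1` carries fluoro in place of trifluoromethyl on an aromatic carbon, para to a large group: fluoro in place of trifluoromethyl on an aromatic carbon. Within the data shown here, the one measured step at this place is no change at the digits printed from compound 1 to compound 3 (within the scatter), with trifluoromethyl in place of chloro. Among the measured compounds shown here, the value of compound 2 is a limit, and no measured step ties it to this change. In this assay the expected move is no change at the digits printed from compound 3 to compound 4 (within the scatter), which would lie within the scatter and favour neither direction. Compound 4 is estimated at 1000 nM, with an expected range of 400 nM to 3000 nM.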

Compound 4, concentration for 50% growth inhibition: 1000 nM
Beside the measured number, compound 4's estimate shows no gap at the digits printed; the measured number falls inside the stated range.
By their numbers in this assay, from the lowest: compounds 1, 3 and 4 (each within the scatter of the next). At a limit, above all of these: compound 2.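

In this assay, the place on the aromatic carbon, para to a large group, now shows no change at the digits printed from compound 3 to compound 4 (within the scatter) and no change at the digits printed from compound 1 to compound 4 (within the scatter), so fluoro, chloro and trifluoromethyl read alike there. Compound 4 also ties compound 2 to the others through a single change, 4-chloro-3-nitrophenyl in place of 4-bromophenyl, with an at least 100-fold lower number from compound 2 to compound 4 (2.00 log units; beyond the scatter). The value of compound 2 is a limit of the assay: the limit of > 100000 nM in this assay, at which 1 of the 4 values shown sits.

On these data alone, whether an amine or a methoxy group at this place would read alike stays open. So does whether the chloro or the nitro of the 4-chloro-3-nitrophenyl group accounts for the large step.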